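The source may hold more compounds than are shown below. What is called first, only, known or untested is meant among the compounds shown, and "the series" means these compounds.

Compound 1 `CN(C)CCCOc1ccc(CN2CC[C@H](NC(=O)c3cccs3)C2)cc1` and compound 2 `CN(C)CCCOc1ccc(CN2CC[C@H](NC(=O)c3ccco3)C2)cc1` share one core and differ only in the aromatic ring attached to the carbonyl carbon. In an assay on HEK293 cells for binding affinity to Urotensin-2 receptor (Homo sapiens), read by radioligand binding (a higher number here means a weaker inhibitor, a lower number a stronger inhibitor), compound 1 gives only a limit, < 10000 nM. In this assay compound 2 likewise gives only a limit, < 10000 nM. The step that the two limits leave unreadable from compound 1 to compound 2 cannot be read because the limit of < 10000 nM in this assay, at which 2 of the 2 values shown sit, hides both values. Compound 3 `CN(C)CCCOc1ccc(CN2CC[C@H](NC(=O)c3cc4ccccc4o3)C2)cc1` differs from compound 2 by 1-benzofuran-2-yl in place of furan-2-yl on a carbonyl carbon. Going by the values given here, no measured step gives a size for this change, and because the limit of < 10000 nM in this assay, at which 2 of the 2 values shown sit, leaves both values unresolved the expected step is a step that the limit leaves unreadable from compound 2 to compound 3. Compound 3 is therefore estimated at 8000 nM, within 1000 nM to 30000 nM.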

Compound 3, inhibition constant: 2510 nM
The estimate for compound 3 lay 3.2-fold (0.50 log units) above the measured number; low and high end bracket the measured number.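

Neither the step from compound 1 to compound 3 nor the step from compound 2 to compound 3 can be read, and the cause is a shared limit: the limit of < 10000 nM in this assay, at which 2 of the 3 values shown sit. The compounds shown leave open how much 1-benzofuran-2-yl changes binding relative to furan-2-yl or thiophen-2-yl.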